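This account rests on a few compounds, and the source may have more. Where it says the series, first, only, none or still open, it means among the compounds named here.

Three compounds share one core and differ only in the aromatic group attached to a sulfur at the end of a short chain. Compound 3 `CCCCN(O)C(=O)Nc1cc([C@@H]2CC[C@@H](c3cc(OC)c(OC)c(OC)c3)O2)cc(OC)c1OCCSc1cccc(Br)c1` carries a 3-bromophenyl there; in an assay for displacement of a labelled ligand from platelet-activating factor receptor (Homo sapiens) (on this read-out higher numbers stand for weaker inhibition and lower numbers for stronger inhibition), compound 3 gives 22 nM. Compound 1 `CCCCN(O)C(=O)Nc1cc([C@@H]2CC[C@@H](c3cc(OC)c(OC)c(OC)c3)O2)cc(OC)c1OCCSc1ccc(Br)cc1` carries a 4-bromophenyl instead and gives 21 nM in this assay; the step of a 1.0-fold higher number from compound 1 to compound 3 (0.02 log units; within the scatter) is within the scatter, so the two compounds are indistinguishable on this read-out. Compound 2 `CCCCN(O)C(=O)Nc1cc([C@@H]2CC[C@@H](c3cc(OC)c(OC)c(OC)c3)O2)cc(OC)c1OCCS(=O)(=O)c1c(F)c(F)cc(F)c1F` differs more, carrying an oxidised sulfur and a tetrafluorophenyl, and gives 285 nM in this assay, a clearly higher number than compound 3. Compound 3 therefore sits among the lower numbers, together with compound 1, while compound 2 stands apart.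

Compound 4 `CCCCN(O)C(=O)Nc1cc([C@@H]2CC[C@@H](c3cc(OC)c(OC)c(OC)c3)O2)cc(OC)c1OCCSc1ccc(OC)cc1` is the next step: 4-methoxyphenyl in place of 3-bromophenyl on a sulfur. Going by the values given here, the only step that bears on it, a 1.0-fold higher number from compound 1 to compound 3 (0.02 log units; within the scatter), shows that moving a bromine around the ring changed nothing; no measured step shows what a methoxy group does here. The sulfur itself is unchanged, unlike in compound 2. The expectation for compound 4 is therefore a small step, a 1.4-fold higher number from compound 3 to compound 4 (0.13 log units; within the scatter), probably within the scatter. Compound 4 is estimated at 30 nM, with a range from 12 nM to 80 nM.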

Compound 4, half-maximal inhibitory concentration: 39 nM
The estimate for compound 4 lay 1.3-fold (0.11 log units) below the measured number, and the stated range covers the measured number.
By their numbers in this assay, from the lowest: compounds 1, 3 and 4 (each within the scatter of the next); then compound 2.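

Replacing the 3-bromophenyl on the sulfur with a 4-methoxyphenyl gives a 1.8-fold higher number from compound 3 to compound 4 (0.25 log units; within the scatter) in this assay, and methoxy in place of bromo on an aromatic carbon gives a 1.9-fold higher number from compound 1 to compound 4 (0.27 log units; within the scatter) in the same assay. The earlier compounds shown here showed only that a bromine could sit at either of two places on this ring, whereas these steps show that compounds 1, 3 and 4 cannot be told apart even when the bromine gives way to a different group, one counted with a hydrogen-bond acceptor. Nothing available explains this result.

On these data alone, what an amine or a carboxylic acid on this ring would do remains open. As far as these compounds go, it is also open whether the oxidised sulfur, the tetrafluorophenyl or both together set compound 2 apart, since it differs from the others in both features at once.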